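This account rests on a few compounds, and the source may have more. Where it says the series, first, only, none or still open, it means among the compounds named here.

Among the measured compounds shown here, compound 3 `O=C(Nc1nc(-c2ccccc2)nc2c1nnn2Cc1ccccc1)C1CCCCC1` gives 12 nM in an assay (strain Wistar) for displacement of a labelled ligand from adenosine receptor A1 (Rattus norvegicus), read by scintillation counting (a higher number here means a weaker inhibitor, a lower number a stronger inhibitor), and stands lowest of the three numbers known so far. Compound 2 `O=C(Nc1nc(-c2ccccc2)nc2c1nnn2Cc1ccccc1)c1ccc(Cl)cc1` gives 108 nM, and compound 1 `COc1ccccc1C(=O)Nc1nc(-c2ccccc2)nc2c1nnn2Cc1ccccc1` gives 1520 nM. The steps among them all lie beyond the scatter: a 14-fold lower number from compound 1 to compound 2 (1.15 log units; beyond the scatter), a 130-fold lower number from compound 1 to compound 3 (2.10 log units; beyond the scatter) and a 9.0-fold lower number from compound 2 to compound 3 (0.95 log units; beyond the scatter). Compound 4 `O=C(Nc1nc(-c2ccccc2)nc2c1nnn2Cc1ccccc1)c1ccc(C(F)(F)F)cc1` differs from compound 3 in a single place: 4-(trifluoromethyl)phenyl in place of cyclohexyl on a carbonyl carbon. The step that bears most directly on this change is a 9.0-fold lower number from compound 2 to compound 3 (0.95 log units; beyond the scatter), in which a six-membered aromatic ring of carbon only gave way to cyclohexyl and the number fell; the present change runs the other way, from cyclohexyl back to such an aromatic ring, so the number is expected to rise. The step of a 130-fold lower number from compound 1 to compound 3 (2.10 log units; beyond the scatter) points in the same direction, although it involves a different group on the ring. Compound 4 is therefore expected to give 150 nM in this assay, within a range from 40 nM to 550 nM. This corresponds to an expected step of a 13-fold higher number from compound 3 to compound 4 (1.10 log units; beyond the scatter), comparable in size to the earlier step but reversed in direction.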

Compound 4, inhibition constant: 123 nM
Compound 4: middle estimate off by 1.2-fold (0.09 log units), on the high side; the range from low to high includes it.
By their numbers in this assay, from the lowest: compound 3; then compounds 2 and 4 (each within the scatter of the next); then compound 1.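

Replacing cyclohexyl with 4-(trifluoromethyl)phenyl on the carbonyl carbon gives a 10-fold higher number from compound 3 to compound 4 (1.01 log units; beyond the scatter) in this assay, so a second aromatic group now falls short of cyclohexyl, and compound 3 remains the strongest of the four. Trifluoromethyl in place of chloro on an aromatic carbon gives a 1.1-fold higher number from compound 2 to compound 4 (0.06 log units; within the scatter), so this assay does not separate these two groups. The change from 2-methoxyphenyl gives a 12-fold lower number from compound 1 to compound 4 (1.09 log units; beyond the scatter), which matches the step seen with 4-chlorophenyl and leaves compound 1 the weakest of the series.

Nothing available explains these differences. The compounds shown leave open how an unsubstituted phenyl, a 4-aminophenyl group or a straight hexyl chain would compare with cyclohexyl on the same carbonyl carbon.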